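Exchanging One Side Chain on a Shared Core

A few compounds are considered here, and "the series" means these few. Any claim that something is new, unique, unknown or untested is made for them only; others in the source may bear on it.

compound 1 `O=C1c2c[n+]([O-])c3ccccc3c2C(=O)c2c1c1ccccc1n2Cc1cn(C[C@H](O)CO)nn1` gives 8880 nM
compound 2 `CN(C)CCCCn1c2c(c3ccccc31)C(=O)c1c[n+]([O-])c3ccccc3c1C2=O` gives 520 nM
compound 3 `O=C1c2c[n+]([O-])c3ccccc3c2C(=O)c2c1c1ccccc1n2Cc1cn(C[C@@H](O)CO)nn1` has not yet been measured

In a toxicity assay on HEK-293T cells (Homo sapiens) for cytotoxicity, read by MTT assay, with a stated time of 72 h (on this read-out higher numbers stand for weaker inhibition and lower numbers for stronger inhibition), compound 2 has the lower of the two numbers at 520 nM and so shows the stronger inhibition. One change turns it into compound 3 (1-(2,3-dihydroxypropyl)-1H-1,2,3-triazol-4-yl in place of 3-(dimethylamino)propyl on a saturated chain carbon bound to an aromatic nitrogen). In words, 1-(2,3-dihydroxypropyl)-1H-1,2,3-triazol-4-yl takes the place of 3-(dimethylamino)propyl on a saturated chain carbon bound to an aromatic nitrogen. Within the data shown here, only one measured step bears on this (a 17-fold lower number from compound 1 to compound 2 (1.23 log units; beyond the scatter)). That large step is the same exchange run the other way, so a similarly large rise is expected in this assay, meaning weaker inhibition. Among the measured compounds shown here, no measured step isolates the stereocentre alone. The estimated step is a 15-fold higher number from compound 2 to compound 3 (1.19 log units; beyond the scatter) and it rests on that single comparison. Compound 3 is therefore expected at 8000 nM within a range from 3500 nM to 20000 nM on this scale.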

Compound 3, half-maximal inhibitory concentration: 2030 nM
The estimate for compound 3 lay 3.9-fold (0.60 log units) above the measured number; the whole stated range lies above it.
By their numbers in this assay, from the lowest: compound 2; then compound 3; then compound 1.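

This position is sensitive not only to which side chain it carries but also to that side chain's three-dimensional arrangement. In this assay there is a 4.4-fold lower number from compound 1 to compound 3 (0.64 log units; beyond the scatter), and this gap can be traced to the stereocentre: the fact that compounds 1 and 3 differ only in the configuration as drawn. The cost of leaving the 3-(dimethylamino)propyl chain therefore depends on the configuration of the incoming group, with a 3.9-fold higher number from compound 2 to compound 3 (0.59 log units; beyond the scatter) set against the larger 17-fold lower number from compound 1 to compound 2 (1.23 log units; beyond the scatter) when the same exchange is read with the other configuration.

The compounds shown do not separate the contribution of the triazole ring from that of the two hydroxyl groups, so a triazole carrying a plain propyl chain would be informative. They also leave open whether a primary amine or a morpholine at the end of the chain would keep the lower number of compound 2.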